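The compounds below may be only part of what the source reports. "The series", "measured", "known", "first", "only" and "open" are said of these compounds alone.

Measured so far:
- compound 1 `CSc1[nH]ccc2ncnc1-2`: 9 mg/kg
- compound 2 `[N-]=[N+]=Nc1nccc2ncn([C@H]3C[C@H](O)[C@@H](CO)O3)c12`: > 9 mg/kg

For the measured compounds named here, in a functional assay on the whole organism (Pleural cavity) with Rattus norvegicus as the target (on this read-out higher numbers stand for an effect only at larger amounts of compound and lower numbers for an effect already at smaller amounts), compound 1 gives 9 mg/kg, the only plain number in the set. Going by the values given here, compound 2 yields in this assay only a limit of the assay, > 9 mg/kg, so it gives no number to set beside compound 1; the one comparison available, (the limit of > 9 mg/kg in this assay, at which 1 of the 2 values shown sits), is thus a limit rather than a step. Compound 3 `Sc1[nH]ccc2ncnc1-2` is not yet measured. It differs from compound 1 as hydrogen in place of methyl on a sulfur, the change sitting on the sulfur whose other neighbour is an aromatic carbon. Among the compounds with values here, no measured pair in the set carries a change of this kind, so no step size can be read from the data. The expectation is a step from compound 1 to compound 3 of a 1.3-fold higher number from compound 1 to compound 3 (0.12 log units; within the scatter) in this assay, not clearly beyond the scatter. Compound 3 is therefore estimated at 12 mg/kg in this assay, within 5 mg/kg to 30 mg/kg.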

Compound 3, dose for half-maximal effect: 8 mg/kg
Compound 3: middle estimate off by 1.5-fold (0.18 log units), on the high side, and the stated range covers the measured number.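

Working notes: this is the first reading of a change at the sulfur whose other neighbour is an aromatic carbon. In this assay, hydrogen in place of methyl gives a 1.1-fold lower number from compound 1 to compound 3 (0.05 log units; within the scatter), so for this one pair the read-out does not separate methylsulfanyl from sulfanyl on the shared core. No measured property in the data bears on this step, and the pair offers no account of it.

From the compounds shown here alone, whether a longer chain such as butyl, a benzyl group or an amine at this place would stay equally close to compound 1 remains open, since a single small change gives no trend. Compound 2 gives only a limit of the assay and differs from compound 1 in more than one place, so it adds no readable step: the limit of > 9 mg/kg in this assay, at which 1 of the 3 values shown sits.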